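This account rests on a few compounds, and the source may have more. Where it says the series, first, only, none or still open, it means among the compounds named here.

Measured compounds in an assay on CHO-K1 cells for antagonist activity at transient receptor potential cation channel subfamily V member 1 (Homo sapiens), read by FLIPR and calcium flux, with a stated time of 6 min; a lower number here means a stronger inhibitor, a higher number a weaker inhibitor:
Compound 1, `CC(C)(C)c1cc(CNC(=O)Nc2cccc3[nH]ncc23)n(-c2cccc(C(F)(F)F)c2)n1`, gives 0.3 nM.
Compound 2, `CC(C)(C)c1cc(CNC(=O)Nc2cccc3[nH]ncc23)n(-c2ccc(C(F)(F)F)cc2)n1`, gives 19.6 nM.
Compound 3, `Cn1ncc2c(NC(=O)NCc3cc(C(C)(C)C)nn3-c3cccc(C(F)(F)F)c3)cccc21`, gives 0.6 nM.

Among these three numbers compound 3 holds the second highest place. Its nearest neighbour is compound 1, from which it differs by a methyl in place of hydrogen on an aromatic nitrogen, and that step, a 2.0-fold higher number from compound 1 to compound 3 (0.30 log units; within the scatter), lies within the scatter. Among the measured compounds shown here, its furthest neighbour is compound 2, and no single step links those two.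

Compound 4, `Cn1ncc2c(NC(=O)NCc3cc(C(C)(C)C)nn3-c3ccc(C(F)(F)F)cc3)cccc21`, has not yet been measured. It differs from compound 3 in one place: 4-(trifluoromethyl)phenyl in place of 3-(trifluoromethyl)phenyl on an aromatic nitrogen. The same change has already been made once in this set, on the pair that lacks the methyl on the aromatic nitrogen: a 65-fold higher number from compound 1 to compound 2 (1.82 log units; beyond the scatter). For the measured compounds named here, that step was large and well beyond the scatter, and it is the only measured step that bears on the change from compound 3 to compound 4. A step of similar size and in the same direction is therefore expected here, so that compound 4 is estimated to lie well to the weaker side of compound 3, a 65-fold higher number from compound 3 to compound 4 (1.81 log units; beyond the scatter). The estimate for compound 4 in this assay is 39 nM, with a range from 12 nM to 125 nM.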

Compound 4, inhibition constant: 12.4 nM
Estimate against measurement, compound 4: 3.1-fold (0.50 log units) above; the measured number falls inside the stated range.
By their numbers in this assay, from the lowest: compounds 1 and 3 (each within the scatter of the next); then compounds 4 and 2 (each within the scatter of the next).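

The large penalty for 4-(trifluoromethyl)phenyl in place of 3-(trifluoromethyl)phenyl on this aromatic nitrogen is not confined to the core of compound 1: in this assay it returns on the methylated core as a 21-fold higher number from compound 3 to compound 4 (1.32 log units; beyond the scatter). The size of the step nevertheless depends on the core, since it is smaller with the methyl present than without it, by more than two such steps would normally scatter: the same change on two cores in this assay, a 65-fold higher number (1.82 log units; beyond the scatter) from compound 1 to compound 2 and a 21-fold higher number (1.32 log units; beyond the scatter) from compound 3 to compound 4, 3.2-fold (0.50 log units) apart, beyond the scatter of two such steps. The methyl step, now read with 4-(trifluoromethyl)phenyl as a 1.6-fold lower number from compound 2 to compound 4 (0.20 log units; within the scatter), stays within the scatter on its own, as it did with 3-(trifluoromethyl)phenyl, yet the two readings of that step also lie further apart than the scatter allows, so the two changes do not simply add: the same change on two cores in this assay, a 2.0-fold higher number (0.30 log units; within the scatter) from compound 1 to compound 3 and a 1.6-fold lower number (0.20 log units; within the scatter) from compound 2 to compound 4, 3.2-fold (0.50 log units) apart, beyond the scatter of two such steps.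

The compounds shown leave open whether this dependence on the core would hold for a plain phenyl or a chlorophenyl on the same nitrogen, as they carry only the two trifluoromethyl-bearing groups there. They also leave open how an ethyl group or a longer chain would behave in place of the methyl, and whether either would change the size of the step between the two aryl groups.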